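The source may hold more compounds than are shown below. What is called first, only, known or untested is meant among the compounds shown, and "the series" means these compounds.

Compound 3 `CN1CCN(CC(=O)NCC(=O)N(C)c2ccc(Cl)cc2C(=O)c2ccccc2Cl)CC1` belongs to a small set of three compounds built on one shared core, each carrying a different group at the end of a short chain. In a functional assay on the whole organism with Mus musculus as the target, in the rotarod test (a higher number here means that more compound is needed for the effect, a lower number that less compound is needed), compound 3 gives > 100 mg/kg, which is a limit of the assay rather than a number, as recorded for it (the limit of > 100 mg/kg in this assay, at which 1 of the 3 values shown sits). Compound 1 `CC(C)NCC(=O)NCC(=O)N(C)c1ccc(Cl)cc1C(=O)c1ccccc1Cl` carries isopropylamino at that place, and in this assay compound 1 gives 13 mg/kg. Compound 2 `CC(=O)NCC(=O)N(C)c1ccc(Cl)cc1C(=O)c1ccccc1Cl` carries hydrogen there, and in this assay compound 2 gives 58 mg/kg.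

Compound 4 `CN(C(=O)CNC(=O)CN)c1ccc(Cl)cc1C(=O)c1ccccc1Cl` has not yet been measured; it differs from compound 3 in one place (amino in place of 4-methylpiperazin-1-yl on a saturated chain carbon bound to a carbonyl carbon). For the measured compounds named here, three measured steps bear on this change. a 4.5-fold higher number from compound 1 to compound 2 (0.65 log units; beyond the scatter). an at least 7.6-fold higher number from compound 1 to compound 3 (0.88 log units; beyond the scatter). an at least 1.7-fold higher number from compound 2 to compound 3 (0.23 log units; that floor lies within the scatter). Replacing 4-methylpiperazin-1-yl with amino undoes the change that turned the number of compound 1 into a limit for compound 3, and amino resembles isopropylamino in compound 1 more than it resembles hydrogen in compound 2. The step is therefore expected to be large and towards lower numbers, an at least 5.0-fold lower number from compound 3 to compound 4 (0.69 log units; beyond the scatter). Compound 4 is estimated to give 20 mg/kg in this assay, with a range from 8 mg/kg to 60 mg/kg.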

Compound 4, dose for half-maximal effect: 27.7 mg/kg
Beside the measured number, compound 4's estimate is 1.4-fold (0.14 log units) below it; the range from low to high includes it.
By their numbers in this assay, from the lowest: compound 1; then compound 4; then compound 2. At a limit, above all of these: compound 3.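

In this assay the small amino group on this saturated chain carbon gives a number that falls between those of its two neighbours: it improves on hydrogen (a 2.1-fold lower number from compound 2 to compound 4 (0.32 log units; beyond the scatter)), while putting isopropyl on the same amine nitrogen lowers the number further (a 2.1-fold higher number from compound 1 to compound 4 (0.33 log units; beyond the scatter)). Among hydrogen, amino and isopropylamino, each of these steps lies beyond the scatter, so the amine nitrogen and the isopropyl on it each add something separately, whereas compound 3 goes against this trend even though its 4-methylpiperazin-1-yl group also joins the chain through a nitrogen. Replacing that ring with amino recovers a measurable number, though compound 3 stands at a limit and the size of the step is only a floor (an at least 3.6-fold lower number from compound 3 to compound 4 (0.55 log units; beyond the scatter)): the limit of > 100 mg/kg in this assay, at which 1 of the 4 values shown sits.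

As far as these compounds go, whether the number keeps falling with a larger group on the amine nitrogen, such as tert-butyl or cyclohexyl, remains open. It is also unclear whether the loss in compound 3 comes with any six-membered ring at this place, as a piperidin-1-yl or morpholin-4-yl group could show, or only with the 4-methylpiperazin-1-yl group.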